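The source may hold more compounds than are shown below. What is called first, only, known or untested is meant among the compounds shown, and "the series" means these compounds.

In a functional assay on HEL cells (Homo sapiens) for inhibition (on this read-out lower numbers stand for stronger inhibition and higher numbers for weaker inhibition), two compounds sharing one core have been measured so far. Compound 1 (`CC(C)c1cc(-c2n[nH]c(=O)n2-c2cccc(NC(=O)CCCCCC(=O)NO)c2)c(O)cc1O`) gives 1600 nM and compound 2 (`CC(C)c1cc(-c2n[nH]c(=O)n2-c2cccc(C(=O)NCCCC(=O)NO)c2)c(O)cc1O`) gives 4600 nM in this test. Compound 2 therefore holds the higher number of the pair, meaning the weaker inhibition, and the gap between them lies beyond the usual scatter.

Compound 3 (`CNC(=O)CCCCCCCNC(=O)c1cccc(-n2c(-c3cc(C(C)C)c(O)cc3O)n[nH]c2=O)c1`) differs from compound 2 in one place: 4-(methylcarbamoyl)butyl stands in place of hydroxycarbamoyl on a saturated chain carbon, three bonds along the chain from an amide-type nitrogen (4-(methylcarbamoyl)butyl in place of hydroxycarbamoyl on a saturated chain carbon, three bonds along the chain from an amide-type nitrogen). Going by the values given here, both measured compounds carry hydroxycarbamoyl, and no compound without it has been measured, so the data offer no direct guide to this change.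

With compound 2 at 4600 nM as the starting point, a moderate step towards weaker inhibition is expected in this assay but remains uncertain. The estimated change is a 2.2-fold higher number from compound 2 to compound 3 (0.34 log units; beyond the scatter) and could prove larger or smaller. For compound 3 the expected value is 10000 nM with 3000 nM to 35000 nM as the estimated range.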

Compound 3, half-maximal inhibitory concentration: 4600 nM
For compound 3 the middle estimate is 2.2-fold (0.34 log units) above the measured one, within the range that was stated.
By their numbers in this assay, from the lowest: compound 1; then compounds 2 and 3 (each within the scatter of the next).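

In this assay, putting 4-(methylcarbamoyl)butyl in place of hydroxycarbamoyl on a saturated chain carbon, three bonds along the chain from an amide-type nitrogen, gives no change at the digits printed from compound 2 to compound 3 (within the scatter). Going by these compounds alone, compound 3 is the first compound here without hydroxycarbamoyl, and it shows that, at least on this scaffold and at this level of inhibition, the read-out does not depend on that group being present at this position. Nothing measured alongside these numbers offers an explanation for this outcome.

This single step swaps the end group and lengthens the chain at the same time, so the compounds shown cannot separate what each of the two changes contributes, and the two contributions could either be negligible or offset each other. A compound carrying hydroxycarbamoyl on the longer chain of compound 3, or one ending in a carboxylic acid or a primary amide on either chain length, would help to pull these two changes apart.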